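This account rests on a few compounds, and the source may have more. Where it says the series, first, only, none or still open, it means among the compounds named here.

Measured in a functional assay on A549 cells (Homo sapiens) for antiproliferative activity, read by MTT assay, with a stated time of 72 h; a lower number here means a stronger inhibitor, a higher number a weaker inhibitor:
- compound 1 `O=S1(=O)C=Cc2cccc(Nc3cccc(C(F)(F)F)c3)c21`: 360 nM
- compound 2 `O=S1(=O)C=Cc2cccc(Nc3cccc(F)c3)c21`: 2550 nM

Compound 2 holds the higher of the two numbers, making it the weaker inhibitor of the pair. Compound 3 `O=S1(=O)C=Cc2cccc(Nc3ccc(F)c(F)c3)c21` carries one change from compound 2, fluoro in place of hydrogen on an aromatic carbon, ortho to a fluoro group and para to a large group. Within the data shown here, one measured step bears on this, and only loosely: a 7.1-fold higher number from compound 1 to compound 2 (0.85 log units; beyond the scatter), with fluoro in place of trifluoromethyl. That step is modest but beyond the scatter. Among the measured compounds shown here, it exchanges one group for another, and no measured step adds a fluoro to a hydrogen-bearing carbon. With a single pair as a guide, only a small move towards a lower number is expected in this assay, perhaps not beyond the scatter. The expected step is a 1.6-fold lower number from compound 2 to compound 3 (0.20 log units; within the scatter). The estimate for compound 3 is 1600 nM, with an expected range of 600 nM to 4200 nM.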

Compound 3, half-maximal inhibitory concentration: 2500 nM
Beside the measured number, compound 3's estimate is 1.6-fold (0.19 log units) below it; measured number inside the range.
By their numbers in this assay, from the lowest: compound 1; then compounds 3 and 2 (each within the scatter of the next).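

In this assay, fluoro in place of hydrogen on an aromatic carbon, ortho to a fluoro group and para to a large group, gives a 1.0-fold lower number from compound 2 to compound 3 (0.01 log units; within the scatter). Among these compounds, this is the first measured step at a hydrogen-bearing carbon of this ring, and it shows that a second fluoro here leaves the number within the scatter, whereas the only step beyond the scatter remains the exchange of groups in a 7.1-fold higher number from compound 1 to compound 2 (0.85 log units; beyond the scatter). No supporting data are available to explain this result.

As far as these compounds go, whether a chloro, a methoxy or an amine at this same carbon would also stay within the scatter remains open. Also open, from the compounds shown here alone, is whether the same fluoro added to compound 1, alongside its trifluoromethyl, would give a similarly small step.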